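Swapping an Ester Tail for a Protected Amine

A few compounds are considered here, and "the series" means these few. Any claim that something is new, unique, unknown or untested is made for them only; others in the source may bear on it.

A small set of compounds built on one shared core was tested in an assay on HEK293 cells for displacement of a labelled ligand from NPC1-like intracellular cholesterol transporter 1 (Homo sapiens); on this read-out higher numbers stand for weaker inhibition and lower numbers for stronger inhibition. Compound 1 `COC(=O)CCNC(=O)CN1CN(c2ccccc2)C2(CCN(C(=O)c3ccc(C4CCCCC4)cc3)CC2)C1=O` carries a methoxycarbonyl group at the end of its side chain and gives 12900 nM in this assay, the highest number among the two compounds with a result. Compound 2 `CC(C)(C)OC(=O)N1CCN(C(=O)CN2CN(c3ccccc3)C3(CCN(C(=O)c4ccc(C5CCCCC5)cc4)CC3)C2=O)CC1` gives 3500 nM in this assay, a clearly lower number than compound 1 and a gap that lies beyond the usual scatter. Compound 3 `COC(=O)CCNC(=O)CN1CN(c2ccccc2)C2(CCN(C(=O)c3ccc(C(C)(C)C)cc3)CC2)C1=O` has no numerical result in this assay, reported as "not determined" (no result reported).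

Compound 4 `CC(C)(C)OC(=O)NCCNC(=O)CN1CN(c2ccccc2)C2(CCN(C(=O)c3ccc(C4CCCCC4)cc3)CC2)C1=O` differs from compound 1 in one place: (tert-butoxycarbonyl)amino in place of methoxycarbonyl on a saturated chain carbon, two bonds along the chain from an amide-type nitrogen. Among the measured compounds shown here, no pair of measured compounds shows this exact change, so its effect must be judged from what is known. Compound 4 is expected to reach 7000 nM in this assay, a modest move toward a lower number, because compound 2, which also carries a tert-butoxycarbonyl group on its side chain, gives 3500 nM. The step of a 1.8-fold lower number from compound 1 to compound 4 (0.27 log units; within the scatter) is expected to be small and near the edge of the scatter. The estimate for compound 4 spans from 2500 nM to 20000 nM.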

Compound 4, half-maximal inhibitory concentration: 5500 nM
Estimate against measurement, compound 4: 1.3-fold (0.10 log units) above; the range from low to high includes it.
By their numbers in this assay, from the lowest: compounds 2 and 4 (each within the scatter of the next); then compound 1.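

Replacing the methoxycarbonyl group with (tert-butoxycarbonyl)amino on the same chain carbon gives a 2.3-fold lower number from compound 1 to compound 4 (0.37 log units; beyond the scatter) in this assay. Among the compounds shown here, this is the first change in the set confined to one place, and it shows that the end of this side chain can affect the read-out, although the step here is modest. The swap also alters more than one feature, with 8 heavy atoms entering where 4 leave and 1 hydrogen-bond donor entering where 0 leave, and no measurement here links the step to any one of these differences.

The compounds shown leave open which part of the new group matters, since a free amine or a simple acetamide at the same chain end would separate the contribution of the nitrogen from that of the tert-butoxycarbonyl group. A carboxylic acid in place of the ester, a longer chain carrying the same (tert-butoxycarbonyl)amino group, and this group on compound 3 would show how far the result extends beyond this single pair.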